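This account rests on a few compounds, and the source may have more. Where it says the series, first, only, none or still open, it means among the compounds named here.

Compound 1, `CC1(C)[C@H](c2cccc(Cl)c2)[C@H]1c1cnc(N)s1`, is the weaker of the two measured compounds: in a functional assay on AP1 cells for inhibition of sodium/hydrogen exchanger 1 (Homo sapiens) (on this read-out lower numbers stand for stronger inhibition and higher numbers for weaker inhibition), compound 1 gives 8000 nM, the highest of the two numbers seen so far. Compound 2, `CC1(C)[C@H](c2cccc(Cl)c2)[C@H]1c1c[nH]c(N)n1`, differs from it in one place, and in this assay compound 2 gives 750 nM; this is an 11-fold lower number from compound 1 to compound 2 (1.03 log units; beyond the scatter). Compound 3, `CC1(C)[C@H](c2cc(Cl)cc(Cl)c2)[C@H]1c1cnc(N)s1`, has not yet been measured. It differs from compound 1 in this way: chloro in place of hydrogen on an aromatic carbon. Among the measured compounds shown here, the only measured step swaps the 2-amino-1,3-thiazol-5-yl group for a 2-amino-1H-imidazol-4-yl group and leaves the six-membered aromatic ring of carbon only untouched, so no measured step bears on the present change, and nothing shows how an added chloro affects the number. A step of about the size of the scatter, in either direction, is therefore expected. In this assay compound 3 is estimated at 4500 nM, between 1500 nM and 15000 nM, which would mean a 1.8-fold lower number from compound 1 to compound 3 (0.25 log units; within the scatter).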

Compound 3, half-maximal inhibitory concentration: > 30000 nM
Compound 3: a limit, no number (the forecaster's own chance of this, stated with the estimate: 10%); middle value at least 6.6-fold (0.82 log units) from the limit.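

Among the compounds shown here, the earlier step changed only the 2-amino-1,3-thiazol-5-yl group, so this is the first measured sign that the six-membered aromatic ring of carbon only also affects the result. In this assay, a chloro in place of hydrogen, meta to a chloro group and meta to a large group, gives an at least 3.7-fold higher number from compound 1 to compound 3 (0.57 log units; beyond the scatter), so inhibition weakens beyond the scatter at this position. Compound 3 gives > 30000 nM, which is a limit of the assay and not a number, so the step shows only the least the change costs: the limit of > 30000 nM in this assay, at which 1 of the 3 values shown sits.

The compounds shown leave open whether a smaller fluoro, or a methyl or methoxy group, at this same place would weaken inhibition as well. They also leave open whether this added chloro would have a similar effect on compound 2, which carries the 2-amino-1H-imidazol-4-yl group.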